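A Fluoro Added Beside the Methyl on Compound 2

The source may report more compounds than this note shows. Statements on the series, on what has been measured and on what is new or still open speak of the compounds shown alone.

Compound 1 `CCCCc1ccc(-c2cc(=O)c3c(o2)C(CC)(CC)C(=O)C(CC)=C3O)cc1` gives 111 uM in a functional assay on KB cells (Homo sapiens) for antiproliferative activity, read by sulforhodamine B assay, with a stated time of 3 days; on this read-out lower numbers stand for an effect already at smaller amounts and higher numbers for an effect only at larger amounts of compound.
Compound 2 `CCC1=C(O)c2c(oc(-c3cccc(C)c3)cc2=O)C(CC)(CC)C1=O` gives 49.7 uM in this assay.
Compound 3 `CCC1=C(O)c2c(oc(-c3cc(C)c(OC)cc3C)cc2=O)C(CC)(CC)C1=O` gives 36.6 uM in this assay.

Three compounds sharing one core differ only in the aryl group attached to it. Compound 2 sits second highest of the three numbers in this assay. Its nearest neighbour is compound 3, whose value of 36.6 uM lies within the scatter of compound 2, so the two cannot be ordered against each other. The furthest is compound 1, whose value of 111 uM lies beyond the scatter and therefore stands as a genuinely higher number than that of compound 2.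

The next compound, compound 4 `CCC1=C(O)c2c(oc(-c3ccc(F)c(C)c3)cc2=O)C(CC)(CC)C1=O`, has not yet been measured. It differs from compound 2 in one place: fluoro in place of hydrogen on an aromatic carbon. Going by the values given here, nothing among the measured compounds shows what a fluoro on this ring does, as no measured pair differs in that way. With no guide from a measured step, a change of this kind is expected to give a step from compound 2 to compound 4 of a 1.1-fold lower number from compound 2 to compound 4 (0.04 log units; within the scatter), that is, nothing beyond the scatter. The value of compound 4 in this assay is estimated at 45 uM, with a range from 20 uM to 110 uM.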

Compound 4, concentration for half-maximal effect: 40.5 uM
The estimate for compound 4 lay 1.1-fold (0.05 log units) above the measured number; measured number inside the range.
By their numbers in this assay, from the lowest: compounds 3, 4 and 2 (each within the scatter of the next); then compound 1.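

In this assay, fluoro in place of hydrogen on the aromatic carbon ortho to a methyl group and para to a large group gives a 1.2-fold lower number from compound 2 to compound 4 (0.09 log units; within the scatter). Going by these compounds alone, this is the first step that differs in one place, and it shows that going from 3-methylphenyl to 4-fluoro-3-methylphenyl moves the number by no more than the scatter. The earlier compounds differ from one another in more than one place on the aryl group, so they could not show what this single change does at this position, and no independent measurement here accounts for the size of the step.

As far as these compounds go, whether chloro, methoxy or an amine on this same carbon would also stay within the scatter of compound 2, or would move the number beyond it, remains open. From the compounds shown here alone, it is also open whether fluoro would leave the number equally unmoved without the neighbouring methyl group, or on the aryl groups of compound 1 and compound 3.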